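The source may report more compounds than this note shows. Statements on the series, on what has been measured and on what is new or still open speak of the compounds shown alone.

Measured so far:
Compound 1 `COc1cc(OC)c(/C=C/S(=O)(=O)Nc2cc([N+](=O)[O-])c(OC)c([N+](=O)[O-])c2)c(OC)c1`: 10000 nM
Compound 2 `COc1ccc(NS(=O)(=O)/C=C/c2c(F)c(F)c(F)c(F)c2F)cc1[N+](=O)[O-]`: 100000 nM
Compound 3 `COc1ccc(NS(=O)(=O)/C=C/c2c(F)cc(F)cc2F)cc1`: 75000 nM

In a functional assay on DU-145 cells (Homo sapiens) for cytotoxicity, read by trypan blue exclusion, with a stated time of 96 h (on this read-out lower numbers stand for stronger inhibition and higher numbers for weaker inhibition), compound 2 gives 100000 nM. That number lies within the usual scatter of compound 3 at 75000 nM, so these two cannot be told apart. Compound 1, at 10000 nM, lies lower than compound 2 by more than the scatter.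

The next case is compound 4 `COc1ccc(NS(=O)(=O)/C=C/c2c(F)c(F)c(F)c(F)c2F)cc1`, which has not yet been measured. It differs from compound 2 in one place, with hydrogen in place of nitro on an aromatic carbon. Within the data shown here, no measured pair shows this change on its own, so any forecast rests on indirect evidence. Compound 1 at 10000 nM and compound 2 at 100000 nM both carry nitro, yet their numbers lie far apart, so nitro alone gives no clear guide. Compound 3, which has no nitro, gives 75000 nM in this assay, close to compound 2. A change beyond the scatter is therefore not expected in this assay, and any shift is expected to be small and towards a lower number. The expected change is a 1.7-fold lower number from compound 2 to compound 4 (0.22 log units; within the scatter). For compound 4 the estimated value is 60000 nM, with an expected range from 15000 nM to 150000 nM.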

Compound 4, half-maximal inhibitory concentration: 10000 nM
Compound 4: middle estimate off by 6.0-fold (0.78 log units), on the high side; the measured number lies below the stated range.
By their numbers in this assay, from the lowest: compounds 1 and 4 (each within the scatter of the next); then compounds 3 and 2 (each within the scatter of the next).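

Hydrogen in place of nitro now has a direct reading in this assay: on this aromatic carbon, ortho to a methoxy group, the change gives a 10-fold lower number from compound 2 to compound 4 (1.00 log units; beyond the scatter). The earlier compounds shown here could not show this, since none of them formed a pair differing in this one place, and the step shows that, with the rest of the structure held constant, this position is not indifferent to what it carries: the compound with hydrogen has the lower number, which on this read-out means stronger inhibition. Nothing measured here explains the step, so its cause remains unknown.

This is a single pair, so it leaves open whether the number depends on removing nitro specifically or would respond in a similar way to other groups at this place, such as an amine, a nitrile or a chlorine atom. It also leaves open whether the same change would give a step of similar size with a different fluorine pattern on the other ring, as in compound 3.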